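The source may report more compounds than this note shows. Statements on the series, on what has been measured and on what is new or still open speak of the compounds shown alone.

Compound 1 `O=C(NNc1ccccc1Cl)c1cccc(NS(=O)(=O)c2cnc(O)nc2O)c1`: 2090 nM
Compound 2 `O=C(NNc1ccccc1F)c1ccccc1NS(=O)(=O)c1cnc(O)nc1O`: > 20000 nM, a limit
Compound 3 `O=C(NNC(=O)c1ccccc1F)c1ccc(NS(=O)(=O)c2cnc(O)nc2O)cc1`: > 20000 nM, a limit

All three compounds were tested in a functional assay on MDA-MB-231 cells (Homo sapiens) for antiproliferative activity, read by MTT assay, with a stated time of 24 h; on this read-out lower numbers stand for stronger inhibition and higher numbers for weaker inhibition. In this assay, among the compounds with values here, compound 1 gives 2090 nM, the only actual number so far. Compound 2 is reported only as a limit, > 20000 nM. Compound 3 is likewise reported only as a limit, > 20000 nM. The remaining evidence therefore comes down to a single ceiling: the limit of > 20000 nM in this assay, at which 2 of the 3 values shown sit.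

Compound 4 `Cc1ccc(C(=O)NNC(=O)c2cccc(NS(=O)(=O)c3cnc(O)nc3O)c2)cc1` has not yet been measured. It departs from compound 1 in one place, with (4-methylphenyl)carbonyl in place of 2-chlorophenyl on an amine nitrogen.

No measured step between any two of these compounds shows what such an exchange does, so the size of the change has to be judged from the values alone. The estimate starts from compound 1 at 2090 nM and leans towards weaker inhibition. Most of the series sits at the ceiling, as the limit of > 20000 nM in this assay, at which 2 of the 3 values shown sit, records. The expected change is a 3.3-fold higher number from compound 1 to compound 4 (0.52 log units; beyond the scatter), a moderate step beyond the usual scatter, though that estimate is loose. For compound 4 the estimated value is 7000 nM, with an expected range from 1500 nM to 25000 nM.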

Compound 4, half-maximal inhibitory concentration: > 20000 nM
Compound 4 ended at the assay's limit; the forecaster's own chance of this, stated with the estimate: 30%; middle value at least 2.8-fold (0.45 log units) from the limit.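

Within the data shown here, this is the first step measured at this position, an amine nitrogen whose other neighbour is an amide-type nitrogen, and it shows that the core of compound 1 does not tolerate every aryl-bearing group there. In this assay, compound 4 gives > 20000 nM, which is a limit of the assay and not a number. Replacing 2-chlorophenyl with (4-methylphenyl)carbonyl therefore gives an at least 9.5-fold higher number from compound 1 to compound 4 (0.98 log units; beyond the scatter), a change beyond the scatter whose true size the limit leaves unknown, and compound 1 remains the only compound with an actual number: the limit of > 20000 nM in this assay, at which 3 of the 4 values shown sit.

The compounds shown leave open which part of the exchange carries this step, the added carbonyl or the change of the ring substituent from chlorine to methyl, and how far compound 4 lies past the limit. A (2-chlorophenyl)carbonyl group or a 4-methylphenyl group on the same amine nitrogen would separate these two parts, while an unsubstituted phenyl group would show whether the chlorine of compound 1 matters at all.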